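Urea series: dimethylamino in place of methoxy

This account rests on a few compounds, and the source may have more. Where it says the series, first, only, none or still open, it means among the compounds named here.

Measured so far:
Compound 1 `Cc1cc(C)c(NC(=O)N(Cc2ccc(N3CCN(C)CC3)cc2)C2CCCCCC2)c(C)c1` — in a functional assay on a cell-free system (plasma) with sterol O-acyltransferase, Soat (Rattus norvegicus) as the target (on this read-out higher numbers stand for an effect only at larger amounts of compound and lower numbers for an effect already at smaller amounts), compound 1 gives > 1 mg/kg, a limit of the assay.
Compound 2 `O=C(Nc1c(F)cc(F)cc1F)N(Cc1ccc(F)cc1)Cc1cccc(-c2cc[nH]n2)c1` — in this assay compound 2 gives < 0.32 mg/kg, a limit of the assay.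
Compound 3 `COc1ccc(CN(Cc2cccc(-c3cc[nH]n3)c2)C(=O)Nc2c(SC)cc(C)nc2SC)cc1` — in this assay compound 3 gives < 0.1 mg/kg, a limit of the assay.

Where compound 3 stands: its value is a limit only, sitting at the limit of < 0.1 mg/kg in this assay, at which 1 of the 3 values shown sits. The other two values are also limits, one at the limit of < 0.32 mg/kg in this assay, at which 1 of the 3 values shown sits, and one at the limit of > 1 mg/kg in this assay, at which 1 of the 3 values shown sits, so none of the three compounds has a number, and no ranking among them can be read beyond what the limits themselves show. For the measured compounds named here, no two measured compounds differ in one place, so no measured step exists.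

Compound 4 `CSc1cc(C)nc(SC)c1NC(=O)N(Cc1ccc(N(C)C)cc1)Cc1cccc(-c2cc[nH]n2)c1` is the next candidate. It differs from compound 3 by dimethylamino in place of methoxy on an aromatic carbon — dimethylamino in place of methoxy on an aromatic carbon, para to a large group. With no measured step of this kind in hand, the expectation is a change of no more than the usual scatter, in no particular direction, expressed as a step that the limit leaves unreadable from compound 3 to compound 4. Compound 4 is accordingly estimated at 0.08 mg/kg, with a range from 0.02 mg/kg to 0.3 mg/kg, and most likely reported again only as a limit.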

Compound 4, dose for half-maximal effect: < 0.1 mg/kg
Compound 4: a limit, no number (the forecaster's own chance of this, stated with the estimate: 70%); the middle value does not contradict the limit.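

No step can be read from compound 3 to compound 4 in this assay, since both values are limits: the limit of < 0.1 mg/kg in this assay, at which 2 of the 4 values shown sit.

Left open is whether 4-(dimethylamino)benzyl and 4-methoxybenzyl differ at all on this read-out, and how far compound 3 and compound 4 each lie past that limit.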